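The source may report more compounds than this note shows. Statements on the series, on what has been measured and on what is new or still open speak of the compounds shown alone.

Working notes on the urea series. Compound 1 `CCc1ccc(NC(=O)Nc2cc(C)nc3ccccc23)cc1` carries an ethyl group on one of its aromatic rings. In an ADME assay on HepG2 cells (Homo sapiens) for cytotoxicity, with a stated time of 72 h (on this read-out higher numbers stand for an effect only at larger amounts of compound and lower numbers for an effect already at smaller amounts), compound 1 gives 17000 nM. Compound 2 `COc1ccc(NC(=O)Nc2cc(C)nc3ccccc23)cc1OC` is the dimethoxy analogue. In this assay compound 2 reaches only the limit of the assay, > 25000 nM, with no number. Compound 3 `Cc1cc(NC(=O)Nc2cnc3ccccc3c2)c2ccccc2n1` differs on the other side of the urea. In this assay compound 3 likewise sits at the limit of the assay, > 25000 nM, with no number. For the measured compounds named here, compound 1 therefore holds the only numerical value in this set; the two remaining values are limits, (the limit of > 25000 nM in this assay, at which 2 of the 3 values shown sit).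

Compound 4 `Cc1cc(NC(=O)Nc2ccc(N)cc2)c2ccccc2n1` has not yet been measured. It differs from compound 1 by amino in place of ethyl on an aromatic carbon. Going by the values given here, no step between two measured compounds that differ in a single place is available, so the size of the step from compound 1 to compound 4 in this assay can only be estimated. Two of the three measured values sit at the limit of the assay, (the limit of > 25000 nM in this assay, at which 2 of the 3 values shown sit), so an expectation near that limit is reasonable, and a shift beyond the usual scatter toward an effect only at larger amounts is expected rather than excluded. Compound 4 is expected at 25000 nM, with a range from 12000 nM to 50000 nM. In this assay the expected step is a 1.5-fold higher number from compound 1 to compound 4 (0.17 log units; within the scatter), and it may well be reported as a limit again.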

Compound 4, half-maximal effective concentration: > 25000 nM
Compound 4: only a limit was reported; the forecaster's own chance of this, stated with the estimate: 55%; the middle value sits exactly at the limit.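

In this assay, the series now has its first step at a single place, with amino in place of ethyl on an aromatic carbon of a six-membered aromatic ring of carbon only, para to a large group: an at least 1.4-fold higher number from compound 1 to compound 4 (0.16 log units; that floor lies within the scatter). This step is only a floor, set by a limit and not by a number, and since that floor lies within the scatter, the exchange cannot be said to move the read-out beyond the usual variation, while its true size has no upper bound. For the compounds shown here, compound 1 remains the only compound in the set with a numerical value, and compound 4 adds one more entry at the limit: the limit of > 25000 nM in this assay, at which 3 of the 4 values shown sit.

The compounds shown leave open whether a longer chain such as propyl, or a carboxylic acid, at this same place would give a numerical value or another limit. They also leave open how the read-out responds to a methyl group or a hydroxyl group there, so the ethyl of compound 1 cannot yet be placed within any trend at this position.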